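This account rests on a few compounds, and the source may have more. Where it says the series, first, only, none or still open, it means among the compounds named here.

Compound 1 `COC(=O)CCN1CCN(c2c(F)cc3c(=O)c(C(=O)O)cn(C4CC4)c3c2OC)CC1C` carries a (methoxycarbonyl)methyl group on a saturated chain carbon bound to an amine nitrogen in a ring. In an ADME assay on Vero cells (Chlorocebus sabaeus) for cytotoxicity, read by MTT assay, with a stated time of 72 h (a higher number here means that more compound is tolerated, a lower number that less compound is tolerated), compound 1 gives > 1000 ug/mL, which is a limit of the assay and not a number; compound 1 thus stands at the limit of > 1000 ug/mL in this assay, at which 1 of the 2 values shown sits. Compound 2 `CCOC(=O)CCN1CCN(c2c(F)cc3c(=O)c(C(=O)O)cn(C4CC4)c3c2OC)CC1C` differs from compound 1 at the ester, and in this assay compound 2 is recorded as "not determined" (no result reported). Among the compounds with values here, no step between measured compounds is available from these two entries. Compound 3 `COc1c(N2CCN(C/C(C)=N/NC(N)=O)C(C)C2)c(F)cc2c(=O)c(C(=O)O)cn(C3CC3)c12` is the next entry. Relative to compound 1 the change is a group of 7 heavy atoms (3 carbon, 3 nitrogen, 1 oxygen; no ring) in place of a group of 5 heavy atoms (3 carbon, 2 oxygen; no ring), on a saturated chain carbon bound to an amine nitrogen in a ring. With compound 1 sitting at the limit, no direction can be read from the series, and the change is expected to move the read-out by no more than the scatter, if at all. The estimate for compound 3 in this assay is 1000 ug/mL, between 400 ug/mL and 2500 ug/mL. The step from compound 1 to compound 3 is expected as a number no higher from compound 1 to compound 3 (the limit leaves the size open).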

Compound 3, half-maximal cytotoxic concentration: 500 ug/mL
Beside the measured number, compound 3's estimate is 2.0-fold (0.30 log units) above it; the range from low to high includes it.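

In this assay compound 3 gives 500 ug/mL, the only number among the compounds shown, so this place, on a saturated chain carbon bound to an amine nitrogen in a ring, now has a value that is not a limit. Replacing (methoxycarbonyl)methyl with the group of 7 heavy atoms gives an at least 2.0-fold lower number from compound 1 to compound 3 (0.30 log units; that floor lies within the scatter), so the change leaves no reading of a real drop beyond the scatter. The true size of the step stays open because compound 1 sits at a limit of the assay and not at a number: the limit of > 1000 ug/mL in this assay, at which 1 of the 3 values shown sits.

The compounds shown leave open how a chain ending in a primary amine or a free carboxylic acid at the same place would read in this assay. This single step also cannot separate the hydrogen-bond donors of the entering group from its nitrogen atoms.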